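The source may report more compounds than this note shows. Statements on the series, on what has been measured and on what is new or still open speak of the compounds shown alone.

Compound 1 `COc1ccc(-c2[nH]c3ccccc3c2/C=C(\C#N)S(=O)(=O)c2ccccc2)cc1`: 300 nM
Compound 2 `N#C/C(=C\c1c(-c2ccccc2)[nH]c2ccccc12)C(=O)c1cccs1`: 1200 nM
Compound 3 `O=C(/C(=C\c1c(-c2ccccc2)[nH]c2ccccc12)C(=O)C(F)(F)F)c1ccco1`: 1900 nM

In a functional assay on CCRF-CEM cells (Homo sapiens) for cytotoxicity, read by MTT assay, with a stated time of 96 h (on this read-out lower numbers stand for an effect already at smaller amounts and higher numbers for an effect only at larger amounts of compound), compound 2 stands second highest of the three numbers: compound 3 lies a short way above it, within the scatter, while compound 1 lies well below it, beyond the scatter. Compound 4 `COCCOC(=O)/C(C#N)=C/c1c(-c2ccccc2)[nH]c2ccccc12` has not yet been measured. It differs from compound 2 in one place: 2-methoxyethoxy in place of thiophen-2-yl on a carbonyl carbon. Going by the values given here, no step between two measured compounds matches this change, so its size is uncertain; a moderate rise in this assay is expected, though a step within the scatter cannot be ruled out. Compound 4 is therefore estimated at 3000 nM, with a range from 1000 nM to 10000 nM, which means an expected step of a 2.5-fold higher number from compound 2 to compound 4 (0.40 log units; beyond the scatter).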

Compound 4, half-maximal effective concentration: 1600 nM
Compound 4: middle estimate off by 1.9-fold (0.27 log units), on the high side, and the stated range covers the measured number.
By their numbers in this assay, from the lowest: compound 1; then compounds 2, 4 and 3 (each within the scatter of the next).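

In this assay, going by these compounds alone, replacing thiophen-2-yl with 2-methoxyethoxy on the carbonyl carbon gives a 1.3-fold higher number from compound 2 to compound 4 (0.12 log units; within the scatter) and is the first single-place change seen here. At this place, a five-membered aromatic ring and an open chain with no ring give values within the scatter of each other, so this one replacement shows that the ring is not required to keep the value in this range. Nothing available explains this result. On these data alone, whether the same holds for a carboxylic acid, an amine or a longer chain on this carbonyl carbon remains open.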